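Clearance in rats along a piperidine substituent series

The source may hold more compounds than are shown below. What is called first, only, known or untested is meant among the compounds shown, and "the series" means these compounds.

Measured so far:
compound 1, `COc1cc(C2CCN(C)CC2)ccc1Nc1ncc2ccc(-c3ccccc3OC)n2n1`, 29 mL/min/kg
compound 2, `COc1cc(C2CCN(C(=O)C3CCN3)CC2)ccc1Nc1ncc2ccc(-c3ccccc3OC)n2n1`, 32 mL/min/kg

In an in vivo ADME assay on the whole organism (strain Sprague-Dawley) for pharmacokinetics, with Rattus norvegicus as the target, at a dose of 1 mg/kg by the intravenous route (a higher number here means faster removal of the compound, a lower number slower removal), compound 1 gives 29 mL/min/kg and compound 2 gives 32 mL/min/kg; the step of a 1.1-fold higher number from compound 1 to compound 2 (0.04 log units; within the scatter) shows no difference beyond the scatter. Compound 2 thus stands with the higher of the two numbers, but within scatter of compound 1.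

Compound 3, `COc1cc(C2CCN(CC(N)=O)CC2)ccc1Nc1ncc2ccc(-c3ccccc3OC)n2n1`, is not yet measured. It differs from compound 2 by carbamoylmethyl in place of (azetidin-2-yl)carbonyl on an amine nitrogen in a ring. Among the measured compounds shown here, the only step that bears on it is a 1.1-fold higher number from compound 1 to compound 2 (0.04 log units; within the scatter), where a substantial exchange on the same ring nitrogen left this assay essentially unchanged. With no other information, compound 3 is expected to show no step beyond the scatter, a 1.1-fold lower number from compound 2 to compound 3 (0.03 log units; within the scatter). Compound 3 is therefore estimated at 30 mL/min/kg, with a range from 15 mL/min/kg to 60 mL/min/kg.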

Compound 3, clearance: 12 mL/min/kg
For compound 3 the middle estimate is 2.5-fold (0.40 log units) above the measured one, and the stated range ends above it.
By their numbers in this assay, from the lowest: compound 3; then compounds 1 and 2 (each within the scatter of the next).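

Carbamoylmethyl on the amine nitrogen in the ring brings a 2.7-fold lower number from compound 2 to compound 3 (0.43 log units; beyond the scatter) in this assay and also a 2.4-fold lower number from compound 1 to compound 3 (0.38 log units; beyond the scatter) in the same assay, so compound 3 has the lowest number of the three. The earlier pair had shown no difference beyond the scatter at this position, whereas these steps show that the group on this nitrogen can change clearance in rats, if only modestly. Read from compound 1, the change is carbamoyl in place of hydrogen on the saturated chain carbon bound to that nitrogen, and no measurement shown here explains why the number falls.

Still open, on these data alone, is whether the carbamoyl group is needed for the lower number, or whether a carboxylic acid or a hydroxyl on the same chain carbon would give a similar result. A longer chain carrying the carbamoyl group is also untested among the compounds shown.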